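Shorter nitrile chain on the aromatic nitrogen: compound 4

This account rests on a few compounds, and the source may have more. Where it says the series, first, only, none or still open, it means among the compounds named here.

Three compounds of the series carry numbers in an assay for inhibition of Amine oxidase [flavin-containing] B (Rattus norvegicus); a lower number here means a stronger inhibitor, a higher number a weaker inhibitor. Within the data shown here, compound 1 `COc1ccc(COc2ccc(-c3nn(CCC#N)c(=O)o3)cc2)cc1` gives 27 nM, compound 2 `N#CCCCn1nc(-c2ccc(OCc3ccccc3)cc2)oc1=O` gives 410 nM, and compound 3 `N#CCCCCn1nc(-c2ccc(OCc3ccccc3)cc2)oc1=O` gives 490 nM, the highest of the three; compound 1 lies well apart from compound 3 but differs from it in two places, so no single step links that pair. The one-place step a 1.2-fold higher number from compound 2 to compound 3 (0.08 log units; within the scatter) lies within the scatter.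

Compound 4 `CC(C#N)Cn1nc(-c2ccc(OCc3ccccc3)cc2)oc1=O` differs from compound 3 by 1-cyanoethyl in place of 3-cyanopropyl on a saturated chain carbon bound to an aromatic nitrogen. Among the measured compounds shown here, the only step on this chain, a 1.2-fold higher number from compound 2 to compound 3 (0.08 log units; within the scatter), was small, so little effect of chain length is expected; the branched, shorter group itself is untested. The step from compound 3 to compound 4 is expected as a 1.4-fold lower number from compound 3 to compound 4 (0.15 log units; within the scatter). Compound 4 is estimated at 350 nM, between 90 nM and 1400 nM.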

Compound 4, half-maximal inhibitory concentration: 2400 nM
Beside the measured number, compound 4's estimate is 6.9-fold (0.84 log units) below it; the measured number lies above the stated range.
By their numbers in this assay, from the lowest: compound 1; then compounds 2 and 3 (each within the scatter of the next); then compound 4.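

In this assay, this position proved sensitive to change: 1-cyanoethyl in place of 3-cyanopropyl gives a 4.9-fold higher number from compound 3 to compound 4 (0.69 log units; beyond the scatter), and 1-cyanoethyl in place of 2-cyanoethyl gives a 5.9-fold higher number from compound 2 to compound 4 (0.77 log units; beyond the scatter). The earlier step on this chain, a 1.2-fold higher number from compound 2 to compound 3 (0.08 log units; within the scatter), had shown no such loss, so the branched group weakens inhibition where the earlier chain change did not. Nothing available explains this loss.

Still open, as far as these compounds go, is how a longer branched chain would behave at this position. An amine or a carboxylic acid in place of the nitrile also remains to be placed in the series.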